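The source may report more compounds than this note shows. Statements on the series, on what has been measured and on what is new or still open speak of the compounds shown alone.

Measured compounds: compound 1 `CNc1ncc2c(-c3ccc(N4CCNCC4)nc3)nn(CC3CCCC3)c2n1` gives 120 nM in an assay for inhibition of tyrosine-protein kinase receptor UFO (Homo sapiens), read by 33P incorporation, in the presence of a further agent that is not named here; on this read-out higher numbers stand for weaker inhibition and lower numbers for stronger inhibition; compound 2 `CNc1ncc2c(-c3ccc(N4CCN(C)CC4)nc3)nn(Cc3cn(Cc4ccccc4)nn3)c2n1` gives 380 nM; compound 3 `CNc1ncc2c(-c3ccc(N4CCN(C(=O)C(C)(C)C)CC4)nc3)nn(Cc3cn(Cc4ccccc4)nn3)c2n1` gives 760 nM.

Compound 2 holds the second highest of the three numbers. Its nearest neighbour is compound 3, reached by the step of a 2.0-fold higher number from compound 2 to compound 3 (0.30 log units; within the scatter), which replaces methyl with (tert-butyl)carbonyl on an amine nitrogen in a ring. Its furthest neighbour is compound 1, whose number is lower and lies beyond the scatter of compound 2.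

Compound 4 `CNc1ncc2c(-c3ccc(N4CCN(C)CC4)nc3)nn(CC3CCCC3)c2n1` is not yet measured. It differs from compound 2 in one place: cyclopentyl in place of 1-benzyl-1H-1,2,3-triazol-4-yl on a saturated chain carbon bound to an aromatic nitrogen. Within the data shown here, no measured pair isolates this change. Compound 1 carries the same cyclopentyl but also lacks the methyl on the ring amine nitrogen, so it differs from compound 2 in two places; its value and that of compound 2 are all the data show, and the lower number sits with compound 1. Among the measured compounds shown here, the only isolated step, from compound 2 to compound 3, concerns the ring amine nitrogen and is within the scatter.

On that basis compound 4 is expected to move toward the number of compound 1, giving an estimated step of a 2.5-fold lower number from compound 2 to compound 4 (0.40 log units; beyond the scatter). The estimate for compound 4 is 150 nM, with a range from 60 nM to 400 nM.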

Compound 4, half-maximal inhibitory concentration: 70 nM
For compound 4 the middle estimate is 2.1-fold (0.33 log units) above the measured one; low and high end bracket the measured number.
By their numbers in this assay, from the lowest: compounds 4 and 1 (each within the scatter of the next); then compounds 2 and 3 (each within the scatter of the next).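

In this assay, the change on a saturated chain carbon bound to an aromatic nitrogen can now be read on its own: cyclopentyl in place of 1-benzyl-1H-1,2,3-triazol-4-yl gives a 5.4-fold lower number from compound 2 to compound 4 (0.73 log units; beyond the scatter), so the larger group with two aromatic rings is not required for inhibition in this pair. With cyclopentyl held constant, methyl in place of hydrogen on the ring amine nitrogen gives a 1.7-fold lower number from compound 1 to compound 4 (0.23 log units; within the scatter), and this pair shows no separation between the two. Nothing available explains the step at the chain position.

Still open, on these data alone, is how a cyclohexyl or a phenyl on the same chain carbon would read. A 1-methyl-1H-1,2,3-triazol-4-yl there would show whether the benzyl or the triazole ring goes with the higher number of compound 2.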